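This account rests on a few compounds, and the source may have more. Where it says the series, first, only, none or still open, it means among the compounds named here.

Among the compounds with values here, in a functional assay on MCF-A cells (Homo sapiens) for cytotoxicity (on this read-out lower numbers stand for stronger inhibition of growth and higher numbers for weaker inhibition of growth), three compounds built on one shared core have numbers so far. Compound 1 `COc1ccc(C2=C(c3ccc(SC)cc3)CC3CCCN3C2=O)cc1Br` gives 6000 nM, compound 2 `CSc1ccc(C2=C(c3ccc(C)c(C)c3)C(=O)N3CCCC3C2)cc1` gives 800 nM, and compound 3 `COc1ccc(C2=C(c3ccc(SC)cc3)CC3CCCN3C2=O)cc1` gives 5000 nM. Compound 3 therefore lies within the scatter of compound 1, and compound 2 is the most potent of the three. Compound 4 `CSc1ccc(C2=C(c3ccc(Br)cc3)C(=O)N3CCCC3C2)cc1` differs from compound 3 in one place: bromo in place of methoxy on an aromatic carbon. This is bromo in place of methoxy on an aromatic carbon, turning 4-methoxyphenyl into 4-bromophenyl.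

The nearest evidence concerns the same aryl group. Swapping 3,4-dimethylphenyl for 4-methoxyphenyl gave a 6.3-fold higher number from compound 2 to compound 3 (0.80 log units; beyond the scatter), and the swap from 3-bromo-4-methoxyphenyl to 3,4-dimethylphenyl gave a 7.5-fold lower number from compound 1 to compound 2 (0.88 log units; beyond the scatter). Removing bromo gave only a 1.2-fold lower number from compound 1 to compound 3 (0.08 log units; within the scatter). Within the data shown here, no measured compound carries 4-bromophenyl, so the direction is uncertain, but a modest drop in the number is expected, namely a 2.8-fold lower number from compound 3 to compound 4 (0.44 log units; beyond the scatter). The estimate for compound 4 is 1800 nM, with an expected range from 600 nM to 5000 nM.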

Compound 4, concentration for 50% growth inhibition: 8000 nM
The estimate for compound 4 lay 4.4-fold (0.65 log units) below the measured number; the measured number lies above the stated range.
By their numbers in this assay, from the lowest: compound 2; then compounds 3, 1 and 4 (each within the scatter of the next).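

In this assay, bromo in place of methoxy on this aromatic carbon, para to a large group, gives no clear separation (a 1.6-fold higher number from compound 3 to compound 4 (0.20 log units; within the scatter)), so the two groups cannot be told apart here. The 4-bromophenyl and 3-bromo-4-methoxyphenyl groups also fall within the scatter of each other (a 1.3-fold higher number from compound 1 to compound 4 (0.12 log units; within the scatter)), whereas 3,4-dimethylphenyl remains clearly apart (a 10-fold higher number from compound 2 to compound 4 (1.00 log units; beyond the scatter)), leaving compound 2 with the lowest number of the four. Nothing available offers a measured reason for this pattern.

The compounds shown leave open whether a single methyl group in place of bromo on this aromatic carbon would bring the number close to that of compound 2. They also leave open how an amine or a carboxylic acid there would read in this assay.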